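The compounds below may be only part of what the source reports. "The series", "measured", "known", "first", "only" and "open" are said of these compounds alone.

Working notes on the series.

Three compounds have numbers in a functional assay on Huh-7 cells (Homo sapiens) for inhibition, read by sulforhodamine B assay, with a stated time of 72 h; on this read-out higher numbers stand for weaker inhibition and lower numbers for stronger inhibition. Compound 1 `CC(c1ccc(-c2ccccc2)c(F)c1)c1nnc2n1N=C(c1ccc(OC(F)(F)F)cc1)CS2` gives 8400 nM. Compound 2 `CC(C)Cc1ccc(C(C)c2nnc3n2N=C(c2ccc(OC(F)(F)F)cc2)CS3)cc1` gives 3600 nM. Compound 3 `CC(C)Cc1ccc(C(C)c2nnc3n2N=C(c2ccc(Br)cc2)CS3)cc1` gives 4900 nM. Within the data shown here, on the numbers so far compound 3 sits with the other two: its gap to compound 2 and its gap to compound 1 are both within the scatter, so no order among the three can be read from these values.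

Among the measured compounds shown here, the one step measured on the same aromatic carbon is a 1.4-fold higher number from compound 2 to compound 3 (0.13 log units; within the scatter), bromo in place of trifluoromethoxy; it stays within the scatter.

Compound 4 `CC(C)Cc1ccc(C(C)c2nnc3n2N=C(c2ccc(C(F)(F)F)cc2)CS3)cc1` differs from compound 3 by trifluoromethyl in place of bromo on an aromatic carbon. The step from compound 2 to compound 3 is the only one that bears on this change, and since it was within the scatter, the expectation is that the step of a 1.1-fold lower number from compound 3 to compound 4 (0.04 log units; within the scatter) is also within the scatter, with no direction claimed. Compound 4 is therefore estimated at 4500 nM, with a range from 2000 nM to 10000 nM.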

Compound 4, half-maximal inhibitory concentration: 8400 nM
Estimate against measurement, compound 4: 1.9-fold (0.27 log units) below; the measured number falls inside the stated range.
By their numbers in this assay, from the lowest: compounds 2, 3, 1 and 4 (each within the scatter of the next, the first and the last beyond it).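

At this carbon of the aromatic ring, the change from trifluoromethoxy to trifluoromethyl gives a 2.3-fold higher number from compound 2 to compound 4 (0.37 log units; beyond the scatter) in this assay and is the only step in the series that exceeds the scatter, so the group here is now shown to matter, if modestly. Bromo remains unresolved from both neighbours: trifluoromethyl in its place gives a 1.7-fold higher number from compound 3 to compound 4 (0.23 log units; within the scatter) and the earlier step from trifluoromethoxy also stays within the scatter, so only the two ends of this small set separate. No data on hand account for the difference between trifluoromethoxy and trifluoromethyl.

Still open, on these data alone, is whether an amine or a carboxylic acid at this carbon would shift the number further, and in which direction. Also open, as far as these compounds go, is whether the same change gives a similar step in the setting of compound 1.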